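Branched Chain on the Indole Nitrogen of Compound 1

A few compounds are considered here, and "the series" means these few. Any claim that something is new, unique, unknown or untested is made for them only; others in the source may bear on it.

Measured compounds:
compound 1, `C/C(=C\C(=O)Nc1ccccc1OCCCC(=O)O)c1ccc2c(ccn2C)c1`, 780 nM
compound 2, `CCCCCCCn1ccc2cc(/C(C)=C/C(=O)Nc3ccccc3OCCCC(=O)O)ccc21`, 120 nM
compound 3, `CC(C)=CCn1ccc2cc(/C(C)=C/C(=O)Nc3ccccc3OCCCC(=O)O)ccc21`, 120 nM

All three compounds share one core and were tested in an assay on Prostate gland for inhibition of steroid 5-alpha-reductase (Rattus norvegicus); on this read-out lower numbers stand for stronger inhibition and higher numbers for weaker inhibition. Among them compound 1 carries the smallest group on the ring nitrogen and gives the highest number, so it is the weakest inhibitor of the three. Compound 2 and compound 3 carry longer groups there, and their numbers are the same at the digits shown.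

The new compound is compound 4, `CCCCCC(CCCCC)n1ccc2cc(/C(C)=C/C(=O)Nc3ccccc3OCCCC(=O)O)ccc21`. Its change from compound 1 is 1-pentylhexyl in place of methyl on an aromatic nitrogen. The entering group has no ring and brings only carbon atoms, like the groups of compound 2 and compound 3, but here the chain is branched at the carbon bound to the nitrogen.

Among the compounds with values here, two measured steps bear on this change: a 6.5-fold lower number from compound 1 to compound 2 (0.81 log units; beyond the scatter) and a 6.5-fold lower number from compound 1 to compound 3 (0.81 log units; beyond the scatter). Both lengthen the group on the nitrogen and both lower the number by the same modest amount, while no change at the digits printed from compound 2 to compound 3 (within the scatter). Within the data shown here, a branched chain of this size has no direct precedent here, so a step of roughly the same size as those two is expected, a 5.2-fold lower number from compound 1 to compound 4 (0.72 log units; beyond the scatter), with wider uncertainty. Compound 4 is therefore estimated at 150 nM, within the range 50 nM to 450 nM.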

Compound 4, half-maximal inhibitory concentration: 25 nM
Compound 4: middle estimate off by 6.0-fold (0.78 log units), on the high side; measured number below the stated range.
By their numbers in this assay, from the lowest: compound 4; then compounds 2 and 3 (each within the scatter of the next); then compound 1.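

In this assay, putting 1-pentylhexyl in place of methyl on the aromatic nitrogen gives the largest step seen at this position (a 31-fold lower number from compound 1 to compound 4 (1.49 log units; beyond the scatter)), so the matching numbers of compound 2 and compound 3 do not mark the lowest number this position can reach. The gain also continues past both earlier chains: relative to heptyl there is a 4.8-fold lower number from compound 2 to compound 4 (0.68 log units; beyond the scatter) and relative to 3-methylbut-2-en-1-yl there is a 4.8-fold lower number from compound 3 to compound 4 (0.68 log units; beyond the scatter), although those two chains could not be told apart. Among these four compounds, then, the group branched at the carbon bound to the nitrogen goes with the lowest number, and the identity of the chain matters at this position in a way that compound 2 and compound 3 alone did not reveal.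

Going by these compounds, whether the branch or simply the larger number of carbons goes with the lower number stays open, and a straight undecyl chain, a smaller branched group such as 1-ethylpropyl, or a chain ending in an amine or a carboxylic acid would help separate these possibilities. No measurement available here explains why this group gives the lower number.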